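The source may report more compounds than this note shows. Statements on the series, on what has been measured and on what is new or still open speak of the compounds shown alone.

Measured in an ADME assay on L02 cells (Homo sapiens) for cytotoxicity, read by MTT assay, with a stated time of 72 h; a lower number here means a stronger inhibitor, a higher number a weaker inhibitor:
compound 1 `COc1cc(/C=C2\CNC/C(=C\c3cc(OC)c(OC)c(OC)c3)C2=O)cc(OC)c1OC` gives 7600 nM
compound 2 `CCN1C/C(=C\c2cc(OC)c(OC)c(OC)c2)C(=O)/C(=C/c2cc(OC)c(OC)c(OC)c2)C1` gives 12800 nM

Compound 2 at 12800 nM stands within the scatter of compound 1. The move to compound 3 `COc1cc(/C=C2\CN(C(=O)CCC(=O)O)C/C(=C\c3cc(OC)c(OC)c(OC)c3)C2=O)cc(OC)c1OC` puts (2-carboxyethyl)carbonyl in place of ethyl on an amine nitrogen in a ring. Among the measured compounds shown here, only one measured step bears on that place, namely a 1.7-fold higher number from compound 1 to compound 2 (0.23 log units; within the scatter) and no measured compound carries the entering group. No step beyond the scatter is therefore expected in this assay and no firm direction can be given. The step expected is a 1.3-fold lower number from compound 2 to compound 3 (0.11 log units; within the scatter) and remains an estimate. Compound 3 is estimated at 10000 nM with an expected range from 3000 nM to 35000 nM for now.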

Compound 3, half-maximal inhibitory concentration: > 60000 nM
Compound 3 was reported as a limit; the forecaster's own chance of this, stated with the estimate: 10%; middle value at least 6.0-fold (0.77 log units) away from the limit.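

The amine nitrogen in the six-membered non-aromatic ring had shown no step beyond the scatter on taking ethyl in place of hydrogen. With (2-carboxyethyl)carbonyl on that nitrogen, the same position gives steps beyond the scatter in both comparisons (an at least 4.6-fold higher number from compound 2 to compound 3 (0.67 log units; beyond the scatter) and an at least 7.8-fold higher number from compound 1 to compound 3 (0.89 log units; beyond the scatter)). In this assay compound 3 is reported only as a limit, not as a number: the limit of > 60000 nM in this assay, at which 1 of the 3 values shown sits.

The compounds shown leave open whether the step goes with the carboxylic acid or with the carbonyl on the nitrogen. An acetyl group or a methyl ester of the chain at that position would separate the two.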